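Swapping chloro for hydrogen on compound 2

The compounds below may be only part of what the source reports. "The series", "measured", "known", "first", "only" and "open" are said of these compounds alone.

Among the compounds with values here, only two compounds have a reading so far. In an ADME assay on Vero cells (Chlorocebus sabaeus) for cytotoxicity, read by crystal violet staining (a higher number here means that more compound is tolerated, a lower number that less compound is tolerated), compound 1 (`c1ccc(/N=N/c2ccc(NC[C@@H]3CCCN4CCCC[C@H]34)c3c2CCCC3)cc1`) gives a half-maximal cytotoxic concentration of 80000 nM. Compound 2 (`Clc1cccc(/N=N/N2CCCCC2)c1`) gives > 100000 nM, which is a limit of the assay and not a number.

Compound 3 (`c1ccc(/N=N/N2CCCCC2)cc1`) has not been measured. It differs from compound 2 by one change, hydrogen in place of chloro on an aromatic carbon.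

Within the data shown here, no measured pair shows what this swap does in this assay, so the expectation rests on compound 2 alone. The expected size of a number no higher from compound 2 to compound 3 (the limit leaves the size open) is none beyond the usual scatter of repeated measurements, with no direction favoured. A reading reported only as a limit would be as likely as a number. For compound 3 the estimated value is 100000 nM, with an expected range from 40000 nM to 200000 nM.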

Compound 3, half-maximal cytotoxic concentration: > 100000 nM
Compound 3: only a limit was reported; the forecaster's own chance of this, stated with the estimate: 50%; the middle value sits exactly at the limit.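

Within the data shown here, compound 2 and compound 3 are both reported only as limits of the assay in this assay, so no step between them can be read. The compounds shown leave open whether hydrogen in place of chloro on an aromatic carbon shifts the half-maximal cytotoxic concentration at all, with both readings stopping at the same ceiling: the limit of > 100000 nM in this assay, at which 2 of the 3 values shown sit.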